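Methyl on the Outer Phenyl Ring in Two Core Arrangements

The compounds below may be only part of what the source reports. "The series", "measured", "known", "first", "only" and "open" are said of these compounds alone.

Three compounds have been measured in a toxicity assay on RMS13 cells (Homo sapiens) for inhibition, with a stated time of 24 h; a lower number here means a stronger inhibitor of growth, a higher number a weaker inhibitor of growth:
compound 1, `CC1=C(C(=O)OCc2ccccc2)C(c2ccc(-c3ccccc3C)cc2)NC(=S)N1Cc1ccc(-c2nnn[nH]2)cc1`, gives 68000 nM
compound 2, `CC1=C(C(=O)OCc2ccccc2)C(c2ccc(-c3ccccc3)cc2)NC(=S)N1Cc1ccc(-c2nnn[nH]2)cc1`, gives 87000 nM
compound 3, `CC1=C(C(=O)OCc2ccccc2)C(c2ccc(-c3ccccc3)cc2)N(Cc2ccc(-c3nnn[nH]3)cc2)C(=S)N1`, gives 72000 nM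

Compounds 1 and 2 share one core and differ in a single place: methyl in place of hydrogen on an aromatic carbon. That change gave a 1.3-fold lower number from compound 2 to compound 1 (0.11 log units; within the scatter), so the two values are indistinguishable here. Compound 3 is built from the same atoms as compound 2, joined differently; the difference between the two cores is not broken down here, and the two values lie within the scatter of each other.

Compound 4, `CC1=C(C(=O)OCc2ccccc2)C(c2ccc(-c3ccccc3C)cc2)N(Cc2ccc(-c3nnn[nH]3)cc2)C(=S)N1`, has not yet been measured. It stands to compound 3 as compound 1 stands to compound 2: methyl in place of hydrogen on an aromatic carbon. The change is the same, made on the core of compound 3 instead. Because a 1.3-fold lower number from compound 2 to compound 1 (0.11 log units; within the scatter) was within the scatter, the step is expected to be small again: a 1.2-fold lower number from compound 3 to compound 4 (0.09 log units; within the scatter). On that basis compound 4 is estimated to give 58000 nM in this assay, expected to fall between 30000 nM and 110000 nM.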

Compound 4, concentration for 50% growth inhibition: 62000 nM
Beside the measured number, compound 4's estimate is 1.1-fold (0.03 log units) below it, within the range that was stated.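

Replacing phenyl with 2-methylphenyl on the core of compound 3 gave a 1.2-fold lower number from compound 3 to compound 4 (0.06 log units; within the scatter) in this assay. Set beside the earlier step, the change reads the same on both cores: the same change on two cores in this assay, a 1.3-fold lower number (0.11 log units; within the scatter) from compound 2 to compound 1 and a 1.2-fold lower number (0.06 log units; within the scatter) from compound 3 to compound 4, 1.1-fold (0.04 log units) apart, within the scatter of two such steps. This shows that, across these two cores, the change carried over without any detectable dependence on the core; it does not show that methyl has a real effect that transfers, since neither step stands out from the scatter, and two cores say nothing about others in the series.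

The compounds shown leave open whether a different group in the same place, such as a longer chain like ethyl or propyl, an amine or a carboxylic acid, would give a step beyond the scatter on either core. They also leave open whether a step of that larger size would carry from one core to the other as closely as this small one did.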